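A few compounds are considered here, and "the series" means these few. Any claim that something is new, unique, unknown or untested is made for them only; others in the source may bear on it.

Of the compounds shown here, two sharing one core have so far been measured in an assay on isolated protein for inhibition of Bile acid receptor (Homo sapiens), read by TR-FRET and LanthaScreen; on this read-out lower numbers stand for stronger inhibition and higher numbers for weaker inhibition. Compound 1, `CC[C@@H](c1nc2ccc(C(=O)O)cc2n1C)N1C(=O)CN(c2ccc(Oc3ccccc3)cc2)C1=O`, gives 210000 nM in this assay. Compound 2, `CC(C)[C@H](c1nc2ccc(C(=O)O)cc2n1C)N1C(=O)CN(c2ccc(Oc3ccccc3)cc2)C1=O`, gives 119000 nM in this assay, and the two numbers stand within the scatter of each other, so neither compound can be set apart from the other on what is seen.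

The next compound, compound 3, `CC(C)[C@@H](c1nc2ccc(C(=O)O)cc2n1C)N1C(=O)CN(c2ccc(Oc3ccccc3)cc2)C1=O`, is the stereochemical partner of compound 2. Between the two, (the two compounds have the same atoms and bonds and differ only in configuration as drawn: 1 of 1 stereo elements differ; a stereocentre at a saturated chain carbon is drawn R in compound 2 and S in compound 3). Among the measured compounds shown here, no pair among the measured compounds shows how a change of configuration at this stereocentre acts on this assay, so nothing in the numbers at hand points in either direction. Both measured compounds sit at very weak inhibition, and compound 3 is expected to remain in that broad region, though an inversion of configuration alone can move a value considerably. The step from compound 2 to compound 3 is therefore expected to be a 1.3-fold higher number from compound 2 to compound 3 (0.10 log units; within the scatter). Compound 3 is estimated at 150000 nM, within a range from 20000 nM to 1000000 nM.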

Compound 3, half-maximal inhibitory concentration: 175000 nM
Estimate against measurement, compound 3: 1.2-fold (0.07 log units) below; measured number inside the range.
By their numbers in this assay, from the lowest: compounds 2, 3 and 1 (each within the scatter of the next).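

In this assay, a pair of compounds now isolates the configuration at this saturated chain carbon, and inverting it gives a step that stays within the scatter (a 1.5-fold higher number from compound 2 to compound 3 (0.17 log units; within the scatter)). The comparison bears on configuration alone: the fact that compounds 2 and 3 differ only in the configuration as drawn. The new compound also gives a second one-place comparison, in which methyl in place of hydrogen on a saturated chain carbon bound to two saturated chain carbons likewise stays within the scatter (a 1.2-fold lower number from compound 1 to compound 3 (0.08 log units; within the scatter)), so neither change sets these compounds apart, and all three remain at very weak inhibition.

The compounds shown leave open whether a cyclohexyl or a phenyl group in place of this chain would give a step beyond the scatter, and whether configuration would then begin to matter at this carbon. They also leave open what an amine or an amide in place of the carboxylic acid would do, since the carboxylic acid and the phenoxy group are the same in all three compounds.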